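Adding a Methoxy Group: Expected Change in Cytotoxicity

The source may hold more compounds than are shown below. What is called first, only, known or untested is meant among the compounds shown, and "the series" means these compounds.

Measured compounds:
compound 1, `COc1ccc(-c2cc(/C=C/C(=O)c3ccc(N)cc3)[nH]n2)cc1`: 92%
compound 2, `COc1ccc(C(=O)/C=C/c2cc(-c3cc(OC)c(OC)c(OC)c3)n[nH]2)cc1OC`: 86%
compound 3, `COc1ccc(-c2cc(/C=C/C(=O)c3ccc(N)cc3)[nH]n2)cc1OC`: 94%

In a functional assay on OVCAR-5 cells (Homo sapiens) for cytotoxicity, read by sulforhodamine B assay, with a stated time of 48 h, tested at 1 uM (on this read-out lower numbers stand for a stronger effect and higher numbers for a weaker effect at the one concentration tested), compound 1 gives 92%, compound 3 gives 94% and compound 2 gives 86%; all three lie within the usual scatter of one another, so no order among them can be read. Compound 3 arises from compound 1 by methoxy in place of hydrogen on an aromatic carbon, and that step gave a number 2 percentage points higher from compound 1 to compound 3 (within the scatter). The difference between the core of compound 1 and the core of compound 2 is not broken down here. Compound 4, `COc1cc(C(=O)/C=C/c2cc(-c3cc(OC)c(OC)c(OC)c3)n[nH]2)cc(OC)c1OC`, arises from compound 2 by methoxy in place of hydrogen on an aromatic carbon. The surroundings are not identical: in compound 4 the carbon is also meta to a methoxy group, so this is the same kind of change rather than the same change. The step of a number 2 percentage points higher from compound 2 to compound 4 (within the scatter) is expected to stay small, resting on compound 3 having shown a number 2 percentage points higher from compound 1 to compound 3 (within the scatter). Compound 4 is therefore estimated at 88% in this assay.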

Compound 4, a percentage reported as activity, at one concentration (the size of the read-out at that concentration, not a potency): 89%
Estimate against measurement, compound 4: 1 percentage points below; measured number inside the range.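

In this assay, methoxy in place of hydrogen on an aromatic carbon gave a number 3 percentage points higher from compound 2 to compound 4 (within the scatter). Set side by side, the two examples of this change agree: the same change on two cores in this assay, a number 2 percentage points higher (within the scatter) from compound 1 to compound 3 and a number 3 percentage points higher (within the scatter) from compound 2 to compound 4, 1 percentage points apart, within the scatter of two such steps This shows that the change left the read-out within the scatter on both cores, so its small size carried from one core to the other at this one concentration; it does not show that the methoxy group has a real effect of its own, and two pairs make no rule for other cores.

The compounds shown leave open whether a different group in this place, such as a carboxylic acid or a longer chain like butoxy, would move the number beyond the scatter. How any of these compounds behaves at other concentrations also stays open.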